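Chlorine on the phenyl ring and inhibition of paw edema

The source may hold more compounds than are shown below. What is called first, only, known or untested is meant among the compounds shown, and "the series" means these compounds.

Measured so far:
Compound 1, `N#Cc1c(-c2ccccc2)nc(SCC(=O)Nn2c(COc3ccc(Cl)cc3Cl)nc3ccccc3c2=O)[nH]c1=O`, 80.8%
Compound 2, `Cn1c(SCC(=O)Nn2c(COc3ccc(Cl)cc3Cl)nc3ccccc3c2=O)nc(-c2ccc(Cl)cc2)c(C#N)c1=O`, 80.8%
Compound 3, `N#Cc1c(Cl)nc(SCC(=O)Nn2c(COc3ccc(Cl)cc3Cl)nc3ccccc3c2=O)nc1-c1ccccc1`, 53.9%

Of the compounds shown here, three have been tested in a functional assay on the whole organism (strain albino) for inhibition, with Rattus norvegicus as the target, read by paw edema, with stated times of 1 h and 0.5 h, at a dose of 100 mg/kg by the oral route; on this read-out lower numbers stand for less inhibition and higher numbers for more inhibition at the one dose given (going by the name of the read-out). Compound 1 and compound 2 each give the same number in this assay, so the two values show no difference between them. Compound 3 stands lowest of the three: its value lies beyond the scatter below both compound 1 and compound 2, by the same margin in each case. Compound 3 and compound 1 differ in more than one place, as do compound 3 and compound 2, so no single step can be read from these pairs.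

Compound 4, `N#Cc1c(Cl)nc(SCC(=O)Nn2c(COc3ccc(Cl)cc3Cl)nc3ccccc3c2=O)nc1-c1ccc(Cl)cc1`, has not yet been measured in this assay. It differs from compound 3 only by chloro in place of hydrogen on an aromatic carbon, placed on the six-membered carbon ring para to a large group. Compound 2 carries the same 4-chlorophenyl, but it also differs from compound 1 elsewhere, so its number says nothing on its own about this one change.

Among the measured compounds shown here, with no single-change step among the measured compounds, the expected step from compound 3 to compound 4 in this assay, a number 4.1 percentage points higher from compound 3 to compound 4 (within the scatter), is estimated as small, without direction beyond the scatter. Compound 4 is therefore expected to give about 58% in this assay, within a range from 40% to 76%.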

Compound 4, a percentage reported as inhibition, in the whole organism at one dose (the size of the read-out at that dose, not a potency): 61.5%
Estimate against measurement, compound 4: 3.5 percentage points below; measured number inside the range.
By their numbers in this assay, from the lowest: compounds 3 and 4 (each within the scatter of the next); then compounds 1 and 2 (each within the scatter of the next).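

The change from phenyl to 4-chlorophenyl now has a reading of its own in this assay: a number 7.6 percentage points higher from compound 3 to compound 4 (within the scatter). Among the compounds shown here, none of the earlier pairs isolated this one place, and this pair shows that chloro in place of hydrogen, para to a large group, leaves the number within the scatter at this dose, so the step gives no direction. Nothing at hand offers an explanation for this result.

From the compounds shown here alone, whether a methoxy group, an amine or a carboxylic acid at the same place on the phenyl ring would also stay within the scatter remains open. Going by these compounds, because compound 1 and compound 2 differ in more than one place, it also remains open whether the same change from phenyl to 4-chlorophenyl would read alike on the core of compound 1.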